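A few compounds are considered here, and "the series" means these few. Any claim that something is new, unique, unknown or untested is made for them only; others in the source may bear on it.

Measured compounds: compound 1 `Cc1ccc(C2CNN=C2S(=O)(=O)CC2=NCCO2)cc1` with 41.3%; compound 2 `O=S(=O)(CC1=NCCS1)C1=NNCC1c1ccc(Cl)cc1` reported as "not active" (no number reported).

In a functional assay, tested at 50 ug/mL (a higher number here means a stronger effect of the compound at the concentration tested, a lower number a weaker effect), compound 1 gives 41.3%, while compound 2 was reported without a number as "not active" (no number reported), so no single figure places compound 2 on the scale. Compound 3 `O=S(=O)(CC1=NCCO1)C1=NNCC1c1ccc(Cl)cc1` has not been tested. It differs from compound 2 by a group of 5 heavy atoms (3 carbon, 1 nitrogen, 1 oxygen; one five-membered non-aromatic ring with 2 hetero atoms) in place of a group of 5 heavy atoms (3 carbon, 1 nitrogen, 1 sulfur; one five-membered non-aromatic ring with 2 hetero atoms), on a saturated chain carbon bound to a sulfonyl sulfur. Among the measured compounds shown here, since compound 2 lacks a number, no step can be stated, and any expected shift in this assay rests on the change alone. For compound 3 the activity in this assay is estimated at 25%, with a range from 5% to 50%.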

Compound 3, a percentage reported as activity, at one concentration (the size of the read-out at that concentration, not a potency): "not active" (no number reported)
Nothing numeric was reported for compound 3; there is nothing to compare the estimate with.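

In this assay, compound 2 and compound 3 both lack a number, so no step can be read between them. No evidence bears on this result. From the compounds shown here alone, whether exchanging the sulfur-containing ring for the oxygen-containing ring changes the effect in this assay remains open.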